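The source may hold more compounds than are shown below. What is called first, only, known or untested is meant among the compounds shown, and "the series" means these compounds.

In a functional assay on HCT-116 cells (Homo sapiens) for inhibition, read by MTT assay, with a stated time of 96 h (a lower number here means a stronger inhibitor of growth, a higher number a weaker inhibitor of growth), compound 1 `O=C(NCCCCCCSSCCCCCCNC(=O)c1cc(-c2ccncc2)n[nH]1)c1cc(-c2ccncc2)n[nH]1` gives 8930 nM, while compound 2 `CC(C)C(=O)SCCCCCCNC(=O)c1cc(-c2ccncc2)n[nH]1` gives 22700 nM. This is the higher of the two numbers, and the gap between them lies beyond the scatter. Compound 3 `O=C(NCCCCCCS)c1cc(C2CCCCC2)n[nH]1` gives > 50000 nM, which is a limit of the assay and not a number. Compound 4 `CSCCCCCCNC(=O)c1cc(-c2ccncc2)n[nH]1` has not yet been measured. It differs from compound 2 by methyl in place of isopropylcarbonyl on a sulfur, with methyl in place of isopropylcarbonyl on a sulfur. Within the data shown here, no measured pair of compounds shows this change, so the expectation remains loose. A modest shift toward weaker growth inhibition is expected in this assay, and it may not exceed the scatter: the estimated change is a 1.4-fold higher number from compound 2 to compound 4 (0.15 log units; within the scatter). For compound 4, the estimated value is 32000 nM, with an expected range of 14000 nM to 50000 nM.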

Compound 4, concentration for 50% growth inhibition: > 50000 nM
Compound 4 was reported as a limit; the forecaster's own chance of this, stated with the estimate: 35%; at least 1.5-fold (0.19 log units) between middle value and limit.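

In this assay, methyl in place of isopropylcarbonyl on a sulfur gives an at least 2.2-fold higher number from compound 2 to compound 4 (0.34 log units; beyond the scatter), the first step measured at this position. The group on this sulfur therefore matters for growth inhibition, and the smaller methyl does not keep what compound 2 shows. Compound 4 is a limit and not a number, so how far the step runs cannot be told: the limit of > 50000 nM in this assay, at which 2 of the 4 values shown sit.

On these data alone, whether an acetyl or benzoyl group on this sulfur would keep the growth inhibition of compound 2 stays open. So does how a free thiol would compare on the core of compound 2.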